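The source may hold more compounds than are shown below. What is called first, only, known or untested is meant among the compounds shown, and "the series" means these compounds.

Measured so far in a functional assay on ECV-304 cells (Homo sapiens) for cytotoxicity; a higher number here means a weaker inhibitor, a lower number a stronger inhibitor:
compound 1 `Cc1ccc(/C=C2\SC(=S)N(NS(=O)(=O)c3ccccc3)C2=O)cc1` gives > 50000 nM.
compound 2 `O=C1/C(=C/c2ccc([N+](=O)[O-])cc2)SC(=S)N1NS(=O)(=O)c1ccccc1` gives > 50000 nM.
compound 3 `O=C1/C(=C/c2cc(F)ccc2F)SC(=S)N1NS(=O)(=O)c1ccccc1` gives > 50000 nM.

For compound 1 this value is a limit of the assay, not a number. The same holds for compound 2. It holds for compound 3 as well. So compound 1 stands where every measured compound stands: the limit of > 50000 nM in this assay, at which 3 of the 3 values shown sit. Compound 4 `Cc1ccc(/C=C2\SC(=S)N(NS(=O)(=O)c3ccccc3)C2=O)cc1C` differs from compound 1 in one place: methyl in place of hydrogen on an aromatic carbon. Within the data shown here, no measured step involves this change, and the steps a step that the two limits leave unreadable from compound 1 to compound 2, a step that the two limits leave unreadable from compound 1 to compound 3 and a step that the two limits leave unreadable from compound 2 to compound 3 all run between limits, so their sizes cannot be read. The step of a number no higher from compound 1 to compound 4 (the limit leaves the size open) is therefore expected to be none beyond the scatter, with compound 4 most likely again at the limit. Compound 4 is estimated at 50000 nM in this assay, within 20000 nM to 100000 nM.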

Compound 4, half-maximal inhibitory concentration: > 50000 nM
Compound 4: only a limit was reported; the forecaster's own chance of this, stated with the estimate: 85%; the middle value sits exactly at the limit.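

Compound 4 gives > 50000 nM as a limit of the assay and not a number, so its steps to compound 1, compound 2 and compound 3 cannot be read. The compounds shown leave open how far any of them truly differs from another in this assay: the limit of > 50000 nM in this assay, at which 4 of the 4 values shown sit.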